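The compounds below may be only part of what the source reports. "The series", "measured", "known", "first", "only" and "open" are said of these compounds alone.

Measured compounds:
compound 1, `CCCn1c(N2CCN(C)CC2)nc2ccccc21`, gives 380 nM in a functional assay on ileum for inhibition of histamine H1 receptor (Cavia porcellus); a lower number here means a stronger inhibitor, a higher number a weaker inhibitor
compound 2, `CCOCCn1c(N2CCCN(Cc3ccccc3)CC2)nc2ccccc21`, gives 15 nM in this assay
compound 3, `CCOCCn1c(N2CCN(c3ccccc3)CC2)nc2ccccc21`, is reported only as a limit of > 10000 nM in this assay

Of the two numbers, compound 1 carries the higher one; the nearest measured compound is compound 2, whose lower number lies beyond the usual scatter. The reading for compound 3 is a limit, not a number: the limit of > 10000 nM in this assay, at which 1 of the 3 values shown sits.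

Compound 4 has the structure `CN1CCN(c2nc3ccccc3n2CCOc2ccccc2)CC1`. It keeps the shared core of compound 1 and changes one place: phenoxy in place of methyl on a saturated chain carbon, two bonds along the chain from an aromatic nitrogen. Among the measured compounds shown here, no pair of measured compounds differs in this place alone, and compounds 2 and 3 differ from compound 1 in more than one place, so the measured values give no direct reading of this change; they show only that the chain carrying the core can be altered without loss, as compound 2 shows, and that it can also be paired with loss, as compound 3 shows.

The step from compound 1 to compound 4 is expected to be small and downward, a 2.5-fold lower number from compound 1 to compound 4 (0.40 log units; beyond the scatter), perhaps not much beyond the scatter. Compound 4 is accordingly estimated at 150 nM in this assay, with a range from 40 nM to 600 nM.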

Compound 4, half-maximal inhibitory concentration: 6.9 nM
Estimate against measurement, compound 4: 22-fold (1.34 log units) above, and the stated range ends above it.
By their numbers in this assay, from the lowest: compound 4; then compound 2; then compound 1. At a limit, above all of these: compound 3.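

In this assay, phenoxy in place of methyl on a saturated chain carbon, two bonds along the chain from an aromatic nitrogen, gives a 55-fold lower number from compound 1 to compound 4 (1.74 log units; beyond the scatter) and so counts as a large step. Among the compounds shown here, this is the first change in a single place that can be read in this set, and it shows that this position on the chain is far from indifferent to what it carries: the larger phenoxy group, with its aromatic ring and its oxygen, goes with a much stronger inhibitor while the rest of compound 1 stays as it is. The values shown offer no measured property that would explain this step.

The compounds shown do not separate the contribution of the oxygen from that of the aromatic ring, so it stays open how a methoxy, a phenyl or a benzyl group would read at this same place. Also open, on these data alone, is whether a chlorophenoxy group, or a longer chain ending in phenoxy, would keep or lose the gain seen with compound 4.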